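Swapping the Amine on a Thiocarbonyl Carbon

This account rests on a few compounds, and the source may have more. Where it says the series, first, only, none or still open, it means among the compounds named here.

Measured so far:
compound 1, `CC(C)N(C(=S)SCc1oc2ccccc2c(=O)c1Cl)C(C)C`, 23600 nM
compound 2, `O=c1c(Cl)c(CSC(=S)N2CCOCC2)oc2ccccc12`, 4100 nM
compound 3, `CC(C)N(C(=S)SCc1cc(=O)c2ccccc2o1)C(C)C`, > 40000 nM

In a functional assay on MDA-MB-435S cells (Homo sapiens) for antiproliferative activity, read by MTT assay, with a stated time of 72 h (a lower number here means a stronger inhibitor, a higher number a weaker inhibitor), compound 1 gives 23600 nM. Compound 2 differs from it by morpholin-4-yl in place of diisopropylamino on a thiocarbonyl carbon, and the step is a 5.8-fold lower number from compound 1 to compound 2 (0.76 log units; beyond the scatter). For compound 3 the number is only a limit of the assay, > 40000 nM. The core of compound 3 differs from that of compound 1 by hydrogen in place of chloro on an aromatic carbon, and the step is an at least 1.6-fold higher number from compound 1 to compound 3 (0.22 log units; that floor lies within the scatter); it remains a floor because the limit of > 40000 nM in this assay, at which 1 of the 3 values shown sits, is where compound 3 sits. Among the measured compounds shown here, compound 4, `O=c1cc(CSC(=S)N2CCOCC2)oc2ccccc12`, has not been measured; it differs from compound 3 by morpholin-4-yl in place of diisopropylamino on a thiocarbonyl carbon, the same change as the one between compound 1 and compound 2, at a place described in the same words. Resting on a 5.8-fold lower number from compound 1 to compound 2 (0.76 log units; beyond the scatter) and on the limit of compound 3, the expected step is an at least 3.3-fold lower number from compound 3 to compound 4 (0.52 log units; beyond the scatter). Compound 4 is therefore expected to give 12000 nM, between 4000 nM and 40000 nM, in this assay.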

Compound 4, half-maximal inhibitory concentration: 22200 nM
Compound 4: the middle estimate sits 1.9-fold (0.27 log units) below what was measured; the measured number falls inside the stated range.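

In this assay, morpholin-4-yl in place of diisopropylamino on the core without chloro gives an at least 1.8-fold lower number from compound 3 to compound 4 (0.25 log units; that floor lies within the scatter). This agrees in direction with the earlier step but, as a floor, does not show on its own that the change carries over to this core. Whether the change is equally large on both cores stays undecided: the same change on two cores in this assay, a 5.8-fold lower number (0.76 log units; beyond the scatter) from compound 1 to compound 2 and an at least 1.8-fold lower number (0.25 log units; that floor lies within the scatter) from compound 3 to compound 4; the limit leaves it open whether they differ

Hydrogen in place of chloro on an aromatic carbon gives a 5.4-fold higher number from compound 2 to compound 4 (0.73 log units; beyond the scatter), and its size with the two amines cannot be compared either: the same change on two cores in this assay, an at least 1.6-fold higher number (0.22 log units; that floor lies within the scatter) from compound 1 to compound 3 and a 5.4-fold higher number (0.73 log units; beyond the scatter) from compound 2 to compound 4; the limit leaves it open whether they differ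

The compounds shown leave open how other amines on the thiocarbonyl carbon, such as piperidine or dimethylamine, would behave on either core. They also leave open what bromo or methyl in place of chloro would give.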